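From phenyl to 3,4-dimethoxyphenyl on a carbonyl carbon

The source may hold more compounds than are shown below. What is called first, only, known or untested is meant among the compounds shown, and "the series" means these compounds.

Compound 1 (`O=C(NC(=S)Nc1cccc(-c2nc3ccccc3[nH]2)c1)c1ccccc1`) is the starting point. In a functional assay on HUVEC cells (Homo sapiens) for inhibition, read by colorimetric assay and crystal violet staining, with a stated time of 72 h (a higher number here means a weaker inhibitor, a lower number a stronger inhibitor), compound 1 gives > 10000 nM as its reading, which is a limit of the assay and not a number. The structure to be tested next is compound 3 (`COc1ccc(C(=O)NC(=S)Nc2cccc(-c3nc4ccccc4[nH]3)c2)cc1OC`), which keeps the core of compound 1 and changes one group. It carries 3,4-dimethoxyphenyl in place of phenyl on a carbonyl carbon. Among the measured compounds shown here, no pair of measured compounds differs in just one place, so no measured step can show how large this change might be. For the measured compounds named here, the only actual number comes from compound 2 (`CCOc1ccc(C(=O)NC(=S)Nc2cc(-c3nc4ccccc4[nH]3)ccc2C)cc1OCC`), which differs from compound 1 in more than one place. Going by the values given here, with compound 2 at 6000 nM in this assay as the sole guide, a modest shift toward a stronger inhibitor is expected, though it may not be large. The estimated size of the change is an at least 1.4-fold lower number from compound 1 to compound 3 (0.15 log units; that floor lies within the scatter) in this reasoning. Compound 3 is expected at 7000 nM with an estimated range from 2500 nM to 15000 nM in this assay when it is measured.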

Compound 3, half-maximal inhibitory concentration: 5000 nM
Estimate against measurement, compound 3: 1.4-fold (0.15 log units) above; measured number inside the range.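

In this assay, among the compounds shown here, replacing phenyl with 3,4-dimethoxyphenyl on a carbonyl carbon is the only difference between these two structures, and it gives the first step that can be read at this position: an at least 2.0-fold lower number from compound 1 to compound 3 (0.30 log units; that floor lies within the scatter). This means that the change moves the reading to a real number, with compound 3 at 5000 nM. The printed floor of the step does not by itself separate the change from the usual variation between repeated measurements. Only a floor can be given, and not a full size, because the reading of compound 1 is a limit of the assay and not a number: the limit of > 10000 nM in this assay, at which 1 of the 3 values shown sits.

The compounds shown leave open how far the true step extends beyond that floor, and whether both methoxy groups of the 3,4-dimethoxyphenyl are needed for it. They also give no answer on how the same shared core would read with a single methoxy group, a fluorine atom or an amine on the phenyl ring at this position.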